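A few compounds are considered here, and "the series" means these few. Any claim that something is new, unique, unknown or untested is made for them only; others in the source may bear on it.

Of the compounds shown here, three have numbers so far in a functional assay on K562 cells (Homo sapiens) for cytotoxicity, read by MTT assay, with a stated time of 24 h (a higher number here means a weaker inhibitor, a lower number a stronger inhibitor), and a fourth is pending. Compound 3 (`COc1cc(/C=C2\CN(C)C/C(=C\c3ccc(F)cc3)C2=O)cc(OC)c1`) gives 11300 nM there, which lies within the scatter of compound 1 (`CN1C/C(=C\c2ccc(C(C)(C)C)cc2)C(=O)/C(=C/c2ccccc2F)C1`) at 18200 nM and clearly apart from compound 2 (`CN1C/C(=C\c2ccc(C#N)cc2)C(=O)/C(=C/c2ccccc2F)C1`) at 2670 nM on the lower side.

The next entry is compound 4 (`COc1cc(/C=C2\CN(C)C/C(=C\c3ccc(Br)cc3)C2=O)cc(OC)c1`), which differs from compound 3 by one exchange: bromo in place of fluoro on an aromatic carbon in words, bromo in place of fluoro on an aromatic carbon, para to a large group, or 4-fluorophenyl to 4-bromophenyl.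

Within the data shown here, only one measured step bears on this, and only loosely: a 6.8-fold lower number from compound 1 to compound 2 (0.83 log units; beyond the scatter) for cyano in place of tert-butyl on an aromatic carbon. That step is modest but beyond the scatter. It involves a different pair of groups and a different partner on the shared core, so it sets no size for the present exchange. Among the measured compounds shown here, no measured pair has fluoro and bromo trading places.

With compound 3 at 11300 nM as the anchor, a change within the scatter of this assay is expected, with no firm direction. The expected step is a 1.1-fold lower number from compound 3 to compound 4 (0.05 log units; within the scatter) and no more than that is claimed. For compound 4 the estimated value is 10000 nM with an expected range from 4500 nM to 22000 nM in this read-out.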

Compound 4, half-maximal inhibitory concentration: 7420 nM
Estimate against measurement, compound 4: 1.3-fold (0.13 log units) above; the measured number falls inside the stated range.
By their numbers in this assay, from the lowest: compound 2; then compounds 4, 3 and 1 (each within the scatter of the next, the first and the last beyond it).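

In this assay, bromo in place of fluoro on an aromatic carbon, para to a large group, gives a 1.5-fold lower number from compound 3 to compound 4 (0.18 log units; within the scatter) and so leaves the two compounds within the scatter of each other; at this position, with the partner carried by compound 3 and compound 4 on the shared core, the read-out does not separate these two halogens. Among these compounds, this is the first measured pair in which fluoro and bromo trade places, and it sits apart from a 6.8-fold lower number from compound 1 to compound 2 (0.83 log units; beyond the scatter), which lies beyond the scatter but involves different groups and a different partner, so the two steps set no common scale for substitution at this position. No measurement at hand speaks to the cause of this result.

Going by these compounds, it remains open whether an amino group, a hydroxy group or a carboxylic acid at the same place would stay within the scatter of fluoro and bromo or move as far as the nitrile of compound 2 does from the tert-butyl of compound 1. Also open, on these data alone, is whether the same halogen exchange stays as small with the partner that compound 1 and compound 2 carry on the shared core.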